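The source may report more compounds than this note shows. Statements on the series, on what has been measured and on what is new or still open speak of the compounds shown alone.

Compound 1 `COc1ccc(C2=C(c3ccccn3)C(=O)N3CCCC3C2)cc1` gives 104000 nM in a functional assay on HCT-116 cells (Homo sapiens) for cytotoxicity; on this read-out higher numbers stand for weaker inhibition and lower numbers for stronger inhibition.
Compound 2 `COc1ccc(C2=C(c3cccnc3)C(=O)N3CCCC3C2)cc1` gives 79000 nM in this assay.
Compound 3 `COc1ccc(C2=C(c3ccncc3)C(=O)N3CCCC3C2)cc1` gives 19000 nM in this assay.

Compound 3 holds the lowest number of the three; the step of a 4.2-fold lower number from compound 2 to compound 3 (0.62 log units; beyond the scatter) and the step of a 5.5-fold lower number from compound 1 to compound 3 (0.74 log units; beyond the scatter) both lie beyond the scatter. Compound 4 `COc1ccc(C2=C(c3cccs3)C(=O)N3CCCC3C2)cc1` differs from compound 3 by thiophen-2-yl in place of pyridin-4-yl on a double-bonded ring carbon. Among the measured compounds shown here, no measured step swaps a six-membered aromatic ring for a five-membered one; the known steps only move the nitrogen within a pyridyl ring, and those steps were modest at most. Moving the nitrogen away from the pyridin-4-yl arrangement raised the number, so a different ring at the same place is expected to cost some inhibition rather than gain it, giving an expected step of a 2.1-fold higher number from compound 3 to compound 4 (0.32 log units; beyond the scatter). Compound 4 is therefore estimated at 40000 nM, expected between 10000 nM and 150000 nM.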

Compound 4, half-maximal inhibitory concentration: 5000 nM
For compound 4 the middle estimate is 8.0-fold (0.90 log units) above the measured one, and the stated range ends above it.
By their numbers in this assay, from the lowest: compound 4; then compound 3; then compounds 2 and 1 (each within the scatter of the next).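

At this place on the double-bonded ring carbon, the ring need not be a pyridyl: thiophen-2-yl, a five-membered aromatic ring carrying sulfur, gives a 3.8-fold lower number from compound 3 to compound 4 (0.58 log units; beyond the scatter) and, against the other two pyridyl isomers, a 16-fold lower number from compound 2 to compound 4 (1.20 log units; beyond the scatter) and a 21-fold lower number from compound 1 to compound 4 (1.32 log units; beyond the scatter). Changing the ring itself thus goes further than moving the nitrogen within the pyridyl ring did, and compound 4 holds the lowest number of the four. Nothing measured here explains this gain. Still open, as far as these compounds go, is whether thiophen-3-yl, furan-2-yl or a plain phenyl ring would match compound 4 at this place.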